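Phenyl-to-Hydrogen Changes and Whole-Organism Antagonism

The source may report more compounds than this note shows. Statements on the series, on what has been measured and on what is new or still open speak of the compounds shown alone.

Measured compounds in a functional assay for antagonist activity, with Cavia porcellus as the target; on this read-out lower numbers stand for stronger inhibition and higher numbers for weaker inhibition:
compound 1, `CN(CC#CCCC1(C(O)(c2ccccc2)c2ccccc2)SCCCS1)Cc1ccccc1`: 3170 nM
compound 2, `CN(C)CC#CCCC1(C(O)(c2ccccc2)c2ccccc2)SCCCS1`: 1810 nM
compound 3, `CCN(CC)CC#CCCC1(C(c2ccccc2)c2ccccc2)SCCCS1`: 500 nM

Compound 1 and compound 2 differ by hydrogen in place of phenyl on a saturated chain carbon bound to an amine nitrogen, and this gave a 1.8-fold lower number from compound 1 to compound 2 (0.24 log units; within the scatter). Compound 4, `CCN(CC)CC#CCCC1(Cc2ccccc2)SCCCS1`, is not yet measured; it differs from compound 3 by hydrogen in place of phenyl on a saturated chain carbon bound to an aromatic carbon and a saturated ring carbon. This is the same kind of change as between compound 1 and compound 2, but at a different place: there the carbon is bound to an amine nitrogen, here to an aromatic carbon and a saturated ring carbon. How the core of compound 3 differs from the core of compound 1 is not broken down here. Compound 3 stands lowest of the three numbers in this assay. Among the measured compounds shown here, because the only measured step of this kind, a 1.8-fold lower number from compound 1 to compound 2 (0.24 log units; within the scatter), lay within the scatter, a small step is expected for compound 4, with some allowance for the different place: a 2.8-fold higher number from compound 3 to compound 4 (0.45 log units; beyond the scatter). Compound 4 is thus estimated at 1400 nM, likely between 400 nM and 5000 nM.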

Compound 4, antagonist equilibrium constant: 1960 nM
For compound 4 the middle estimate is 1.4-fold (0.15 log units) below the measured one; low and high end bracket the measured number.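

In this assay, putting hydrogen in place of phenyl on a saturated chain carbon bound to an aromatic carbon and a saturated ring carbon gave a 3.9-fold higher number from compound 3 to compound 4 (0.59 log units; beyond the scatter) as a modest step. This kind of change did not carry over with the same size from one pair to the other: the same change on two cores in this assay, a 1.8-fold lower number (0.24 log units; within the scatter) from compound 1 to compound 2 and a 3.9-fold higher number (0.59 log units; beyond the scatter) from compound 3 to compound 4, 6.9-fold (0.84 log units) apart, beyond the scatter of two such steps. The two pairs differ both in the place of the change and in their cores, so these data do not show which of the two sets the gap, and two steps give no rule for any further core.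

The compounds shown leave open how a piperidine in place of the diethylamine would stand on this read-out. Going by these compounds, the effect of a longer chain also remains open.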